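This account rests on a few compounds, and the source may have more. Where it says the series, first, only, none or still open, it means among the compounds named here.

Measured compounds:

Compound 1, `COc1ccc(-c2cnc3nc(N)nc(N4CCN(c5cc(Cl)cc(Cl)c5)CC4)c3n2)cc1OC`: 3400 nM
Compound 2, `COc1ccc(-c2cnc3nc(N)nc(N4CCN(c5ccc(C)cc5)CC4)c3n2)cc1OC`: 300 nM

Within the data shown here, in a functional assay on cells (T-cell, Homo sapiens) for inhibition (a lower number here means a stronger inhibitor, a higher number a weaker inhibitor), compound 2 holds the lowest of the two numbers; the only neighbour is compound 1, and the step of an 11-fold lower number from compound 1 to compound 2 (1.05 log units; beyond the scatter) puts compound 1 well beyond the scatter from it. The group on the amine nitrogen in a ring is therefore a position where the assay reacts strongly.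

Compound 3, `COc1ccc(-c2cnc3nc(N)nc(N4CCN(Cc5ccccc5)CC4)c3n2)cc1OC`, is the next change at that position: benzyl in place of 4-methylphenyl on an amine nitrogen in a ring. Among the measured compounds shown here, the one step measured so far, an 11-fold lower number from compound 1 to compound 2 (1.05 log units; beyond the scatter), concerns a swap of one aromatic substituent for another on that nitrogen, not the insertion of a one-carbon link between nitrogen and ring; it shows only that this position is sensitive, not which way a benzyl will move. A moderate loss against compound 2 is expected rather than a gain, with wide uncertainty.

Compound 3 is estimated at 1000 nM, within 250 nM to 4000 nM, an expected step of a 3.3-fold higher number from compound 2 to compound 3 (0.52 log units; beyond the scatter) in this assay.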

Compound 3, half-maximal inhibitory concentration: 900 nM
The estimate for compound 3 lay 1.1-fold (0.05 log units) above the measured number; the range from low to high includes it.
By their numbers in this assay, from the lowest: compound 2; then compound 3; then compound 1.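

Benzyl and 4-methylphenyl carry the same atoms joined differently, yet the change in this assay gives a step beyond the scatter (a 3.0-fold higher number from compound 2 to compound 3 (0.48 log units; beyond the scatter)), so this position responds to the arrangement of the group and not only to its composition. The step to benzyl from the other aryl group, (a 3.8-fold lower number from compound 1 to compound 3 (0.58 log units; beyond the scatter)), places compound 3 between compound 2 and compound 1, so an aromatic ring bonded directly to the nitrogen does not by itself set the number: compound 2 and compound 1 both have one and lie on either side of compound 3. Nothing measured here accounts for these differences.

Open, as far as these compounds go, is how a longer chain, such as 2-phenylethyl, or a benzoyl group on the same nitrogen would compare. An unsubstituted phenyl would also be needed to separate the contribution of the methyl from that of the two chlorines.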